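The source may report more compounds than this note shows. Statements on the series, on what has been measured and on what is new or still open speak of the compounds shown alone.

Measured compounds:
compound 1 `CN(C(=O)NC(=O)c1cccc(C(F)(F)F)c1)c1nc(C(F)(F)F)c(C(=O)N/N=C/c2cccc(C(F)(F)F)c2)s1` — 4.6 ug/mL
compound 2 `Cc1nc(N(C)C(=O)NC(=O)c2c(F)cccc2F)sc1C(=O)N/N=C/c1ccc(C(F)(F)F)cc1` — 65.5 ug/mL

Of the compounds shown here, two have been measured in a functional assay on BCG823 cells (Homo sapiens) for inhibition, read by MTT assay, with a stated time of 72 h; a higher number here means a weaker inhibitor, a lower number a stronger inhibitor. Compound 1 gives 4.6 ug/mL, the lower of the two numbers, and compound 2 gives 65.5 ug/mL; the gap between them is well beyond the scatter, so compound 1 is the stronger inhibitor of the pair. The two differ in several places at once, so no single change can be credited with that gap.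

Compound 3 `CN(C(=O)NC(=O)c1ccc([N+](=O)[O-])cc1)c1nc(C(F)(F)F)c(C(=O)N/N=C/c2cccc(C(F)(F)F)c2)s1` has not yet been measured. Relative to compound 1 it carries one change: 4-nitrophenyl in place of 3-(trifluoromethyl)phenyl on a carbonyl carbon. Among the measured compounds shown here, nothing among the measured compounds isolates this exchange, so there is no measured step to lean on. With the rest of compound 1 kept intact, the estimate rests on compound 1 alone.

The step expected from this change is a 1.3-fold higher number from compound 1 to compound 3 (0.12 log units; within the scatter), which is within the scatter and in no firm direction. Compound 3 is therefore expected to give 6 ug/mL in this assay, with a range from 2 ug/mL to 20 ug/mL.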

Compound 3, half-maximal inhibitory concentration: 1.67 ug/mL
The estimate for compound 3 lay 3.6-fold (0.56 log units) above the measured number, outside the stated range (below it).
By their numbers in this assay, from the lowest: compound 3; then compound 1; then compound 2.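

In this assay, the carbonyl carbon whose other neighbour is an amide-type nitrogen now has its first single-place comparison: placing 4-nitrophenyl there in place of 3-(trifluoromethyl)phenyl gives a 2.8-fold lower number from compound 1 to compound 3 (0.44 log units; beyond the scatter). With the rest of compound 1 kept intact, this shows that the aryl group at this place can affect the number in this assay and that 3-(trifluoromethyl)phenyl is not needed to keep it low, although this exchange alters both the substituent and its place on the ring, so the step cannot be divided between those two differences. Nothing available explains why the number falls with this exchange.

The compounds shown leave open whether the lower number follows the nitro group itself or its place on the ring, and how a plain phenyl, or a phenyl carrying an amine or a carboxylic acid in place of the nitro group, would compare at this carbonyl carbon. They also leave open whether the same step would appear with a different group at any other place on the shared core.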